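This account rests on a few compounds, and the source may have more. Where it says the series, first, only, none or still open, it means among the compounds named here.

Compound 3 `Nc1ccccc1NC(=O)c1ccc(Cn2cnc3c(Nc4ccccc4)nc(Cl)nc32)cc1` stands second highest of the three numbers in a functional assay on NCI-H460 cells (Homo sapiens) for antiproliferative activity, read by CCK-8 assay, with a stated time of 72 h, tested at 2 uM (on this read-out lower numbers stand for a weaker effect and higher numbers for a stronger effect at the one concentration tested), where compound 3 gives 42.7%. Within the data shown here, compound 2 `Cc1ccc(Nc2nc(Cl)nc3c2ncn3Cc2ccc(C(=O)Nc3ccccc3N)cc2)cc1` gives 67.3% in this assay, and the step of a number 24.6 percentage points lower from compound 2 to compound 3 (beyond the scatter) is the only single change measured here. Compound 1 `CC(C)n1cnc2c(Nc3ccccc3)nc(NCOCc3ccc(C(=O)Nc4ccccc4N)cc3)nc21` gives 15% in this assay and differs from compound 3 in more than one place, so only its value is known. Compound 4 `Nc1ccccc1NC(=O)c1ccc(Cn2cnc3c(NCc4ccccc4)nc(Cl)nc32)cc1` differs from compound 3 by benzyl in place of phenyl on a nitrogen on an aromatic ring. Among the measured compounds shown here, no measured step bears on this change, so the direction is open. Compound 4 is expected to give about 38% in this assay, within 12% to 64%. The step of a number 4.7 percentage points lower from compound 3 to compound 4 (within the scatter) is therefore estimated to stay within the scatter.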

Compound 4, a percentage reported as inhibition, at one concentration (the size of the read-out at that concentration, not a potency): 44.7%
Estimate against measurement, compound 4: 6.7 percentage points below; low and high end bracket the measured number.
By their numbers in this assay, from the lowest: compound 1; then compounds 3 and 4 (each within the scatter of the next); then compound 2.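

On the nitrogen on an aromatic ring, the change from anilino to benzylamino gives a number 2 percentage points higher from compound 3 to compound 4 (within the scatter) in this assay, so at this position the read-out does not separate phenyl from benzyl. The step of a number 22.6 percentage points lower from compound 2 to compound 4 (beyond the scatter), with benzyl in place of 4-methylphenyl, leaves compound 2 apart from both unsubstituted partners. No evidence on hand accounts for these numbers. The compounds shown leave open whether a methyl on the benzyl ring would match the 4-methylphenyl value. They also leave open how a longer chain such as phenylethyl, or an amine on the ring, would read here.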